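The source may hold more compounds than are shown below. What is called first, only, known or untested is meant among the compounds shown, and "the series" means these compounds.

Compound 1 `CC(=O)OC/C1=C/C[C@](C)(CCC=C(C)C)/C=C/[C@@H](OC(=O)C=C(C)C)[C@](C)(O)/C=C/C1=O` gives 4510 nM in a functional assay on MCF7 cells (Homo sapiens) for antiproliferative activity, read by MTT assay, with a stated time of 48 h; a lower number here means a stronger inhibitor, a higher number a weaker inhibitor. Compound 2 `CC(=O)OC/C1=C/C[C@](C)(CCC=C(C)C)/C=C/[C@@H](OC(=O)C=C(C)C)[C@](C)(OC(C)=O)/C=C/C1=O` gives 3990 nM. Compound 3 `CC(C)=CCC[C@]1(C)/C=C/[C@@H](OC(=O)C=C(C)C)[C@](C)(O)/C=C/C(=O)/C(C=O)=C\C1` gives 12600 nM.

Compound 3 stands highest of the three numbers, that is, as the weakest inhibitor of the set: the step of a 2.8-fold higher number from compound 1 to compound 3 (0.45 log units; beyond the scatter) separates it from compound 1, and compound 2 lies further off still. Compound 4 `CC(C)=CCC[C@]1(C)/C=C/[C@@H](OC(=O)C=C(C)C)[C@](C)(O)/C=C/C(=O)/C(CN=[N+]=[N-])=C\C1` differs from compound 3 in one place: azidomethyl in place of formyl on a double-bonded ring carbon. Going by the values given here, no measured step shows this exact change. The only one that bears on it is a 2.8-fold higher number from compound 1 to compound 3 (0.45 log units; beyond the scatter), where a formyl replaced a longer group on the same ring carbon and the number rose modestly; the step of a 1.1-fold lower number from compound 1 to compound 2 (0.05 log units; within the scatter) concerns another place and stayed within the scatter. Reversing the direction of that first step, a modest fall is expected for compound 4, giving a 1.8-fold lower number from compound 3 to compound 4 (0.26 log units; within the scatter). Compound 4 is therefore estimated at 7000 nM, within 2500 nM to 20000 nM.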

Compound 4, half-maximal inhibitory concentration: 4890 nM
For compound 4 the middle estimate is 1.4-fold (0.16 log units) above the measured one; low and high end bracket the measured number.
By their numbers in this assay, from the lowest: compounds 2, 1 and 4 (each within the scatter of the next); then compound 3.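

On this double-bonded ring carbon, in this assay azidomethyl in place of formyl gives a 2.6-fold lower number from compound 3 to compound 4 (0.41 log units; beyond the scatter) and so undoes the loss seen with formyl. Azido in place of acetoxy on the chain carbon gives a 1.1-fold higher number from compound 1 to compound 4 (0.04 log units; within the scatter) and the two groups cannot be told apart here. Of the three groups compared on this carbon, only formyl stands apart.

On these data alone, whether an aminomethyl group or a carboxylic acid on this carbon would give a similar number stays open. Nothing measured here explains why these groups differ.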